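The source may hold more compounds than are shown below. What is called first, only, known or untested is meant among the compounds shown, and "the series" means these compounds.

Measured compounds:
compound 1 `CN(C)S(=O)(=O)Cc1noc2ccccc12` — 37 mg/kg
compound 2 `CN1CCN(S(=O)(=O)Cc2noc3ccccc23)CC1` — 57 mg/kg

Compound 1 and compound 2 were tested in a functional assay on the whole organism (strain STD-dd) with Mus musculus as the target, in the maximal electroshock model, with a stated time of 2 h; on this read-out lower numbers stand for an effect already at smaller amounts and higher numbers for an effect only at larger amounts of compound. Of the two numbers, compound 1 has the lower one at 37 mg/kg, while compound 2 gives 57 mg/kg; the two lie within the scatter of each other, so no order can be read between them.

The account follows the step from compound 1 to compound 3, whose structure is `CN(C)S(=O)(=O)Cc1noc2ccc(F)cc12`. Among the compounds with values here, the single change is fluoro in place of hydrogen on an aromatic carbon. Within the data shown here, no step between two measured compounds is known that would show how this kind of change plays out in this assay, so the expectation rests on compound 1 alone.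

Compound 3 is expected to give 30 mg/kg, within a range of 15 mg/kg to 60 mg/kg. The estimated step of a 1.2-fold lower number from compound 1 to compound 3 (0.09 log units; within the scatter) is taken to stay within the scatter, with no direction asserted.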

Compound 3, dose for half-maximal effect: 32 mg/kg
Beside the measured number, compound 3's estimate is 1.1-fold (0.03 log units) below it, and the stated range covers the measured number.
By their numbers in this assay, from the lowest: compounds 3, 1 and 2 (each within the scatter of the next).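

Fluoro in place of hydrogen on this aromatic carbon, meta to a fused ring and para to a fused ring, gives a 1.2-fold lower number from compound 1 to compound 3 (0.06 log units; within the scatter) in this assay and so stays within the scatter. This is the first change shown on the six-membered aromatic ring of the core of compound 1, and it shows that this position can carry fluoro with the whole-animal effect kept, while no gain or loss can be read from the step. Nothing measured on these compounds speaks to why the number holds.

From the compounds shown here alone, it remains open whether chloro, methoxy or an amine on the same carbon would move the number beyond the scatter. Also open, going by these compounds, is whether fluoro on another carbon of this ring would leave the number as undisturbed.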